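A few compounds are considered here, and "the series" means these few. Any claim that something is new, unique, unknown or untested is made for them only; others in the source may bear on it.

Of the compounds shown here, three built on related cores have been tested in a functional assay on A549 cells (Homo sapiens) for inhibition, read by sulforhodamine B assay, with a stated time of 48 h; on this read-out lower numbers stand for stronger inhibition and higher numbers for weaker inhibition. Compound 1 `COC(=O)[C@H]1C[C@@H](c2coc3ccccc3c2=O)N(c2ccccc2)O1` reads > 60000 nM, and this is a limit of the assay, not a number. Compound 2 `O=c1c([C@@H]2C[C@H](c3ccccc3)ON2c2ccccc2)coc2cc(Cl)c(Cl)cc12` gives 43000 nM and compound 3 `CCO[C@H]1C[C@@H](c2coc3ccc(F)cc3c2=O)N(c2ccccc2)O1` gives 26400 nM, two values within the scatter of each other.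

Compound 4 `O=c1c([C@@H]2C[C@H](c3ccncc3)ON2c2ccccc2)coc2ccccc12` has not yet been measured. It carries pyridin-4-yl in place of methoxycarbonyl on a saturated ring carbon, next to the ring oxygen of the five-membered non-aromatic ring: pyridin-4-yl in place of methoxycarbonyl on a saturated ring carbon. Among the measured compounds shown here, no step between measured compounds offers a direct guide to this change. Compound 2 also bears a six-membered aromatic ring on that saturated ring carbon and gives 43000 nM, so a modest move towards stronger inhibition is expected in this assay. The expected step is an at least 2.1-fold lower number from compound 1 to compound 4 (0.33 log units; beyond the scatter). A reading at the limit would not be a surprise. For compound 4 the estimate is 28000 nM, with an expected range from 9000 nM to 70000 nM.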

Compound 4, half-maximal inhibitory concentration: 19300 nM
Compound 4: middle estimate off by 1.5-fold (0.16 log units), on the high side, within the range that was stated.
By their numbers in this assay, from the lowest: compounds 4, 3 and 2 (each within the scatter of the next, the first and the last beyond it). At a limit, above all of these: compound 1.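

In this assay, putting pyridin-4-yl in place of methoxycarbonyl on the saturated ring carbon next to the ring oxygen gives an at least 3.1-fold lower number from compound 1 to compound 4 (0.49 log units; beyond the scatter). The earlier compounds shown here offered no step between them, so this pair alone shows that a change at this carbon can move the number beyond the scatter. The step has only a lower bound, since compound 1 stands at a limit of the assay and not at a number: the limit of > 60000 nM in this assay, at which 1 of the 4 values shown sits.

The compounds shown leave open whether the nitrogen of pyridin-4-yl matters at this carbon, or whether another six-membered aromatic ring would read the same on the core of compound 4. They also leave open how an amine, a carboxylic acid or a longer chain would read at this carbon.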